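The compounds below may be only part of what the source reports. "The series", "measured", "known", "first", "only" and "open" are said of these compounds alone.

Measured so far in a physicochemical assay for lipophilicity, read by LC-MS, in phosphate buffer, measured as octanol-water partition, at pH 7.4, tested at 66.7 uM; a lower number here means a more polar compound, a higher number a more lipophilic compound:
compound 1 `Cc1ccc(-c2ccnc(Nc3ccc(N4CCN(C)CC4)c(C(F)(F)F)c3)n2)cc1` gives > 5.85 (a limit of the assay)
compound 2 `CN1CCN(c2ccc(Nc3nccc(-c4cccnc4)n3)cc2C(F)(F)F)CC1` gives 3.53 
compound 3 `CN1CCN(c2ccc(Nc3nccc(-c4ccnc(Cl)c4)n3)cc2C(F)(F)F)CC1` gives 4.3 

Compound 3 holds the higher of the two actual numbers, and the nearest compound is compound 2. The gap between them is a number 0.77 log units higher from compound 2 to compound 3 (beyond the scatter) on this short list. Compound 1 reports only the limit of > 5.85 in this assay, at which 1 of the 3 values shown sits, and so gives no exact number.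

The next compound is compound 4 `CN1CCN(c2ccc(Nc3nccc(-c4cccc([N+](=O)[O-])c4)n3)cc2C(F)(F)F)CC1`, where 3-nitrophenyl stands in place of 2-chloropyridin-4-yl on an aromatic carbon (3-nitrophenyl in place of 2-chloropyridin-4-yl on an aromatic carbon) and the rest of the structure is unchanged.

Among the measured compounds shown here, all the measured steps fall at this same place. Leaving the carbon-only ring of compound 1 gave two large drops, namely a number at least 2.32 log units lower from compound 1 to compound 2 (beyond the scatter) and a number at least 1.55 log units lower from compound 1 to compound 3 (beyond the scatter) in the same assay. The change to compound 4 restores a carbon-only ring, so a rise in this assay is expected. For the measured compounds named here, no compound carrying 3-nitrophenyl has been measured, and 4-methylphenyl is the only carbon-only ring on record, so only part of those large steps is expected to return. The expected change is a number 0.50 log units higher from compound 3 to compound 4 (beyond the scatter) and is estimated as modest in size. The value estimated for compound 4 is 4.8 with an expected range from 4.2 to 5.4 in this series.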

Compound 4, distribution coefficient: 4.5
Compound 4: the middle estimate sits 0.30 log units above what was measured; low and high end bracket the measured number.
By their numbers in this assay, from the lowest: compound 2; then compounds 3 and 4 (each within the scatter of the next). At a limit, above all of these: compound 1.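

In this assay, a carbon-only ring at this place, on an aromatic carbon of a six-membered aromatic ring with 2 nitrogen, does not by itself recover the level of the 4-methylphenyl compound: a number at least 1.35 log units lower from compound 1 to compound 4 (beyond the scatter) remains as a large step. Against the two pyridine rings the result splits, with a number 0.20 log units higher from compound 3 to compound 4 (within the scatter) leaving 3-nitrophenyl and 2-chloropyridin-4-yl unresolved, while a number 0.97 log units higher from compound 2 to compound 4 (beyond the scatter) keeps pyridin-3-yl apart from 3-nitrophenyl, so the earlier link between ring type and the size of the step does not hold across these compounds. The true size of the step from the 4-methylphenyl ring stays unknown, as compound 1 reports a limit and not a number: the limit of > 5.85 in this assay, at which 1 of the 4 values shown sits.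

The compounds shown leave open how much of the remaining gap belongs to the carbon-only ring and how much to the group it carries, a question that a plain phenyl ring at this place would help to separate. Also open is how a ring bearing an amine or a carboxylic acid would read here, and every step shown falls at this one place, so the rest of the structure remains untested.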